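This account rests on a few compounds, and the source may have more. Where it says the series, first, only, none or still open, it means among the compounds named here.

Three compounds share one core and differ only in the group attached to the sulfonyl sulfur. Compound 1 `Cc1cc(C)cc(S(=O)(=O)c2cnc3ccc(F)cc3c2N2CCC(C)CC2)c1` gives 83% in an assay on isolated protein for displacement of a labelled ligand from metabotropic glutamate receptor 5 (Homo sapiens), with a stated time of 60 min, tested at 1 uM; on this read-out lower numbers stand for less inhibition and higher numbers for more inhibition at the one concentration tested (going by the name of the read-out). Compound 2 `Cc1ccc(S(=O)(=O)c2cnc3ccc(F)cc3c2N2CCC(C)CC2)cc1Cl` gives 91% in this assay. Compound 3 `CC1CCN(c2c(S(=O)(=O)c3cccc(Cl)c3)cnc3ccc(F)cc23)CC1` gives 92% in this assay. Compound 3 holds the highest of the three numbers, but every gap to it sits within the scatter, with a number 9 percentage points higher from compound 1 to compound 3 (within the scatter) and a number 1 percentage points higher from compound 2 to compound 3 (within the scatter), as does a number 8 percentage points higher from compound 1 to compound 2 (within the scatter). Compound 4 `CC1CCN(c2c(S(=O)(=O)c3ccc(F)c(Cl)c3)cnc3ccc(F)cc23)CC1` differs from compound 3 by fluoro in place of hydrogen on an aromatic carbon. For the measured compounds named here, none of the measured steps adds a fluoro, and all three steps on this same ring stayed within the scatter, so in this assay no step beyond the scatter is expected. Compound 4 is therefore estimated at 90%, between 80% and 97%, which means an expected step of a number 2 percentage points lower from compound 3 to compound 4 (within the scatter).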

Compound 4, a percentage reported as inhibition, at one concentration (the size of the read-out at that concentration, not a potency): 95%
Estimate against measurement, compound 4: 5 percentage points below; the range from low to high includes it.
By their numbers in this assay, from the lowest: compounds 1, 2, 3 and 4 (each within the scatter of the next, the first and the last beyond it).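

In this assay, fluoro on this aromatic carbon, ortho to a chloro group and para to a large group, leaves the number level with hydrogen (a number 3 percentage points higher from compound 3 to compound 4 (within the scatter)) and with methyl (a number 4 percentage points higher from compound 2 to compound 4 (within the scatter)), so all three are accommodated here without a readable change. For the compounds shown here, the 3-chloro-4-fluorophenyl group gives the only step beyond the scatter in the set, a modest one over 3,5-dimethylphenyl (a number 12 percentage points higher from compound 1 to compound 4 (beyond the scatter)). No evidence is available to explain these steps. Open, going by these compounds, is whether a methoxy group or an amine on this carbon would keep the inhibition, and a single concentration gives no potency to separate compound 2, compound 3 and compound 4.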